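Chloro in Place of Bromo: Compound 4 Expected Near Compound 1

This account rests on a few compounds, and the source may have more. Where it says the series, first, only, none or still open, it means among the compounds named here.

In a functional assay on T47D cells (Homo sapiens) for inhibition, read by CCK-8 assay, with a stated time of 72 h, tested at 10 uM (on this read-out lower numbers stand for less inhibition of growth and higher numbers for more inhibition of growth at the one concentration tested), compound 1 `CN(C)C(=O)c1cc2cnc(Nc3ccc(NC(=O)C4(C(=O)Nc5ccc(Br)cc5)CC4)cc3)nc2n1C1CCCC1` gives 94.3%, the second highest of three numbers. Compound 2 `CN(C)C(=O)c1cc2cnc(Nc3ccc(NC(=O)C4(C(=O)Nc5ccc(O)cc5)CC4)cc3)nc2n1C1CCCC1` gives 95.8%, and the step of a number 1.5 percentage points higher from compound 1 to compound 2 (within the scatter) stays within the scatter. Compound 3 `CN(C)C(=O)c1cc2cnc(Nc3ccc(NC(=O)C4(C(=O)Nc5cccc(F)c5)CC4)cc3)nc2n1C1CCCC1` gives -0.4%; the steps of a number 94.7 percentage points lower from compound 1 to compound 3 (beyond the scatter) and a number 96.2 percentage points lower from compound 2 to compound 3 (beyond the scatter) are both large. Compound 4 `CN(C)C(=O)c1cc2cnc(Nc3ccc(NC(=O)C4(C(=O)Nc5ccc(Cl)cc5)CC4)cc3)nc2n1C1CCCC1` differs from compound 1 by chloro in place of bromo on an aromatic carbon. The step from compound 1 to compound 2 bears most directly on this change, since it also exchanges the group in the same place and left the number within the scatter; the large drops seen for compound 3 come from a 3-fluorophenyl, a different change. Compound 4 is therefore expected to show a number 1.3 percentage points lower from compound 1 to compound 4 (within the scatter), a step not beyond the scatter. The estimated value for compound 4 is 93%, between 80% and 99%.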

Compound 4, percent growth inhibition at one concentration: 95%
Beside the measured number, compound 4's estimate is 2 percentage points below it; the measured number falls inside the stated range.
By their numbers in this assay, from the lowest: compound 3; then compounds 1, 4 and 2 (each within the scatter of the next).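

In this assay, three different groups, bromo, hydroxy and chloro, now give matching numbers at the place para to a large group, with a number 0.7 percentage points higher from compound 1 to compound 4 (within the scatter) and a number 0.8 percentage points lower from compound 2 to compound 4 (within the scatter). The 4-chlorophenyl also stays far from the 3-fluorophenyl, with a number 95.4 percentage points higher from compound 3 to compound 4 (beyond the scatter), so the gap now separates compound 3 from all three other compounds. Nothing available explains these numbers.

On these data alone, whether the collapse in compound 3 follows from the fluoro group or from its place remains open. So does whether an amine or a carboxylic acid at the place para to a large group would keep the number this high.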